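The source may report more compounds than this note shows. Statements on the series, on what has been measured and on what is new or still open speak of the compounds shown alone.

Measured so far in a functional assay on the whole organism for inhibition, with Mus musculus as the target, at a dose of 32 mg/kg by the oral route; on this read-out higher numbers stand for more inhibition at the one dose given (going by the name of the read-out) and lower numbers for less inhibition:
Compound 1 `CSc1ccc2c(c1)c(Cl)c(C(=O)N(C)c1ccccc1)c(=O)n2C` gives -1%.
Compound 2 `CSc1ccc2c(c1)c(N)c(C(=O)N(C)c1ccccc1)c(=O)n2C` gives 22%.
Compound 3 `COc1c(C(=O)N(C)c2ccccc2)c(=O)n(C)c2ccc(SC)cc12` gives 94%.

Compound 3 stands highest of the three in this assay, and both gaps to it lie beyond the scatter: a number 72 percentage points higher from compound 2 to compound 3 (beyond the scatter) and a number 95 percentage points higher from compound 1 to compound 3 (beyond the scatter). The move to compound 4 `CSc1ccc2c(c1)c(S)c(C(=O)N(C)c1ccccc1)c(=O)n2C` makes one change: sulfanyl in place of methoxy on an aromatic carbon. For the measured compounds named here, no measured step swaps methoxy for sulfanyl, so none bears directly on it. What the measured steps do show is that the group at this position changes the read-out a great deal, with two large steps into compound 3 and one modest step, a number 23 percentage points higher from compound 1 to compound 2 (beyond the scatter). Since methoxy is the best of the three groups tried, leaving it is expected to lower inhibition in this assay, by an uncertain amount. Compound 4 is therefore estimated at 45%, within 0% to 90%. For compound 4 this means an expected a number 49 percentage points lower from compound 3 to compound 4 (beyond the scatter).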

Compound 4, a percentage reported as inhibition, in the whole organism at one dose (the size of the read-out at that dose, not a potency): 19%
The estimate for compound 4 lay 26 percentage points above the measured number; measured number inside the range.
By their numbers in this assay, from the lowest: compound 1; then compounds 4 and 2 (each within the scatter of the next); then compound 3.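

In this assay, sulfanyl keeps little of what methoxy gives (a number 75 percentage points lower from compound 3 to compound 4 (beyond the scatter)). It cannot be told apart from amino (a number 3 percentage points lower from compound 2 to compound 4 (within the scatter)) but still stands clear of chloro (a number 20 percentage points higher from compound 1 to compound 4 (beyond the scatter)), so methoxy now stands alone at this position, well clear of the other three groups. Nothing given here explains why.

Open, as far as these compounds go, is how a hydroxyl, an ethoxy or a methylsulfanyl group on this carbon would compare with methoxy. Those groups could show whether the high number goes with the oxygen, the methyl or both together.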